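The source may report more compounds than this note shows. Statements on the series, on what has been measured and on what is new or still open speak of the compounds shown alone.

Of the compounds shown here, three of a shared core have been measured in a functional assay on CHO cells for antagonist activity at prostaglandin E2 receptor EP3 subtype (Homo sapiens), read by FLIPR, with a stated time of 1 h; a lower number here means a stronger inhibitor, a higher number a weaker inhibitor. Compound 1 `CC1(c2ccc(-c3ccc4ccccc4c3)[nH]c2=O)OC(=O)NC1=O` gives 20 nM. Compound 2 `COc1cc(-c2ccc3ccccc3c2)ccc1C1(C)OC(=O)NC1=O` gives 3160 nM. Compound 3 `CC(C)C1(c2cc(Cl)c(-c3ccc4ccccc4c3)[nH]c2=O)OC(=O)NC1=O` gives 50.1 nM, which places compound 3 second highest of the three numbers: compound 1 stands nearest, with a lower number beyond the usual scatter, and compound 2 stands furthest, with a much higher number, also beyond the scatter.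

Compound 4 `CC(C)C1(c2cc(Br)c(-c3ccc4ccccc4c3)[nH]c2=O)OC(=O)NC1=O` has not yet been measured in this assay. It differs from compound 3 in one place: bromo in place of chloro on an aromatic carbon. Among the compounds with values here, no pair of measured compounds shows this exchange of one halogen for another, so nothing in the numbers above fixes the size of the step. For compound 4 the expectation is a step from compound 3 of a 1.1-fold lower number from compound 3 to compound 4 (0.05 log units; within the scatter), that is, no change beyond the scatter in either direction. On that basis compound 4 is estimated at 45 nM, with a range from 20 nM to 110 nM.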

Compound 4, inhibition constant: 39.8 nM
Beside the measured number, compound 4's estimate is 1.1-fold (0.05 log units) above it; the measured number falls inside the stated range.
By their numbers in this assay, from the lowest: compounds 1, 4 and 3 (each within the scatter of the next, the first and the last beyond it); then compound 2.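

Within the data shown here, the exchange of chloro for bromo, on the aromatic carbon ortho to a large group and two atoms from the ring nitrogen, gives the only step that can be read at this position: in this assay it is a 1.3-fold lower number from compound 3 to compound 4 (0.10 log units; within the scatter) and stays within the scatter. Among these compounds, this position therefore takes either halogen with no change that the assay can separate, which the earlier compounds could not show, since no two of them differed in one place. Nothing measured here gives a reason for this result.

As far as these compounds go, whether the same carbon would tolerate a group other than a halogen, such as a methyl, a nitrile or an amine, remains open. From the compounds shown here alone, it is also open whether the two halogens would still read alike with a methyl in place of the isopropyl on the shared core.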